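The compounds below may be only part of what the source reports. "The series", "measured", "known", "first", "only" and "open" are said of these compounds alone.

Measured in a toxicity assay on NIH3T3 cells (Mus musculus) for cytotoxicity, read by resazurin assay; a lower number here means that less compound is needed, a higher number that more compound is needed for the effect:
- compound 1 `CN(C)c1ccc(NCc2cncn2Cc2ccc(-c3ccccc3)cc2)cc1-c1ccccc1`: > 1000 nM (a limit)
- compound 2 `N#Cc1ccc(NCc2cncn2Cc2ccc(-c3ccccc3)cc2)cc1-c1ccccc1`: > 1000 nM (a limit)
- compound 3 `CNC(=O)c1ccc(NCc2cncn2Cc2ccc(-c3ccccc3)cc2)cc1-c1ccccc1`: > 1000 nM (a limit)

Compound 3 has no numerical value, only the limit > 1000 nM. The other two compounds are also reported only as limits, so the series offers no number to anchor on.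

Compound 4 `c1ccc(-c2ccc(Cn3cncc3CNc3ccc(-c4nc5ccccc5s4)c(-c4ccccc4)c3)cc2)cc1` carries 1,3-benzothiazol-2-yl in place of methylcarbamoyl on an aromatic carbon, ortho to a phenyl group: 1,3-benzothiazol-2-yl in place of methylcarbamoyl on an aromatic carbon.

Three measured steps change the substituent on an aromatic carbon: a step that the two limits leave unreadable from compound 1 to compound 2, a step that the two limits leave unreadable from compound 1 to compound 3 and a step that the two limits leave unreadable from compound 2 to compound 3. None has a readable size, and none of them introduces 1,3-benzothiazol-2-yl. Going by the values given here, no step of a particular size or direction can therefore be carried over to this assay. The expectation rests on (the limit of > 1000 nM in this assay, at which 3 of the 3 values shown sit), and compound 4 is expected to stay in that region. The expected step is a step that the limit leaves unreadable from compound 3 to compound 4, and it is likely to be reported again as unreadable. For compound 4 the estimated value is 3000 nM. The expected range for compound 4 runs from 700 nM to 15000 nM.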

Compound 4, half-maximal effective concentration: > 1000 nM
Compound 4 ended at the assay's limit; the forecaster's own chance of this, stated with the estimate: 75%; the middle value does not contradict the limit.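

In this assay compound 4 gives > 1000 nM, a limit. Going by these compounds alone, no step from compound 1, compound 2 or compound 3 to compound 4 can be read, as all four are reported only as limits. The compounds shown leave open where the actual values lie and whether the aromatic-carbon substituent changes them at all.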